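Replacing 3,4-dichlorophenyl with 3-nitrophenyl

The source may hold more compounds than are shown below. What is called first, only, known or untested is meant among the compounds shown, and "the series" means these compounds.

Measured in a physicochemical assay for solubility, in phosphate buffer, at pH 7.4; on this read-out higher numbers stand for higher solubility and lower numbers for lower solubility:
- Compound 1 `CCOC(=O)c1c(-c2cccc(F)c2)[nH]c2cccc(OC)c2c1=O`: > 100000 nM, a limit
- Compound 2 `CCOC(=O)c1c(-c2ccccc2Cl)[nH]c2cccc(OC)c2c1=O`: > 100000 nM, a limit
- Compound 3 `CCOC(=O)c1c(-c2ccc(Cl)c(Cl)c2)[nH]c2cccc(OC)c2c1=O`: 39000 nM

Going by the values given here, compound 3 gives the only actual number here, 39000 nM. For compound 1 and compound 2 the reading is the limit of > 100000 nM in this assay, at which 2 of the 3 values shown sit.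

Compound 4 `CCOC(=O)c1c(-c2cccc([N+](=O)[O-])c2)[nH]c2cccc(OC)c2c1=O` is still unmeasured, and it differs from compound 3 as follows: 3-nitrophenyl in place of 3,4-dichlorophenyl on an aromatic carbon.

Among the compounds with values here, two measured steps bear on this change: an at least 2.5-fold lower number from compound 1 to compound 3 (0.40 log units; beyond the scatter) and an at least 2.5-fold lower number from compound 2 to compound 3 (0.40 log units; beyond the scatter). On these data alone, each ends at the 3,4-dichlorophenyl and starts from a limit, so its full size stays unknown. Within the data shown here, no 3-nitrophenyl compound has been measured yet. Compound 4 gives up the 3,4-dichlorophenyl, so a reversal of an at least 2.5-fold lower number from compound 2 to compound 3 (0.40 log units; beyond the scatter) is expected in this assay, at least in part.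

The expected change is a 2.2-fold higher number from compound 3 to compound 4 (0.34 log units; beyond the scatter). Compound 4 is estimated at 85000 nM, with an expected range from 35000 nM to 100000 nM.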

Compound 4, solubility: 49000 nM
Compound 4: middle estimate off by 1.7-fold (0.24 log units), on the high side; measured number inside the range.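

In this assay there is a 1.3-fold higher number from compound 3 to compound 4 (0.10 log units; within the scatter) and so, at this position next to the ring nitrogen, 3-nitrophenyl and 3,4-dichlorophenyl cannot be told apart. Giving up the 3,4-dichlorophenyl therefore need not lift the number, at least when 3-nitrophenyl enters. Both an at least 2.0-fold lower number from compound 2 to compound 4 (0.30 log units; that floor lies within the scatter) and an at least 2.0-fold lower number from compound 1 to compound 4 (0.30 log units; that floor lies within the scatter) start from a limit and are not shown to pass the scatter.

On these data alone, whether an amine or a carboxylic acid in place of the nitro would shift the number stays open. The full size of those two steps also stays open: the limit of > 100000 nM in this assay, at which 2 of the 4 values shown sit.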